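Moving the trifluoromethyl group: compound 3 to compound 4

A few compounds are considered here, and "the series" means these few. Any claim that something is new, unique, unknown or untested is made for them only; others in the source may bear on it.

Values in a functional assay on MOLT-4 cells (Homo sapiens) for inhibition, read by MTT assay, with a stated time of 72 h (a lower number here means a stronger inhibitor, a higher number a weaker inhibitor), are as follows
compound 1 `COc1cc(NC(C)CCCNC(=O)Nc2cc(C(F)(F)F)cc(C(F)(F)F)c2)c2ncccc2c1` gives 12000 nM
compound 2 `COc1cc(NC(C)CCCNC(=O)NNC(=O)Nc2cccc(F)c2)c2ncccc2c1` gives >= 250000 nM as a limit
compound 3 `COc1cc(NC(C)CCCNC(=O)Nc2ccc(C(F)(F)F)cc2)c2ncccc2c1` gives 20000 nM
compound 4 `COc1cc(NC(C)CCCNC(=O)Nc2cccc(C(F)(F)F)c2)c2ncccc2c1` is not yet measured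

Compound 3 at 20000 nM lies within the scatter of compound 1 on these numbers. The structural change is 3-(trifluoromethyl)phenyl in place of 4-(trifluoromethyl)phenyl on an amide-type nitrogen with 3-(trifluoromethyl)phenyl in place of 4-(trifluoromethyl)phenyl on an amide-type nitrogen. Within the data shown here, the one measured step is an at least 12-fold lower number from compound 2 to compound 3 (1.09 log units; beyond the scatter) and it starts from a limit and exchanges a different group, so it gives no size for this change. Compound 1 at 12000 nM also carries trifluoromethyl groups in that place and stays within the scatter of compound 3, so no step beyond the scatter is expected in this assay here. The expected step is a 1.1-fold lower number from compound 3 to compound 4 (0.05 log units; within the scatter) and it stays within the scatter. Compound 4 is estimated at 18000 nM with an expected range from 9000 nM to 40000 nM for now.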

Compound 4, half-maximal inhibitory concentration: 20000 nM
For compound 4 the middle estimate is 1.1-fold (0.05 log units) below the measured one; the measured number falls inside the stated range.
By their numbers in this assay, from the lowest: compounds 1, 3 and 4 (each within the scatter of the next). At a limit, above all of these: compound 2.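

Trifluoromethyl placement on the aryl group of the amide-type nitrogen makes no visible difference in this assay: no change at the digits printed from compound 3 to compound 4 (within the scatter). Hydrogen in place of trifluoromethyl on an aromatic carbon also stays within the scatter, with a 1.7-fold higher number from compound 1 to compound 4 (0.22 log units; within the scatter). The value of compound 2 is a limit, so an at least 12-fold lower number from compound 2 to compound 4 (1.09 log units; beyond the scatter) gives a bound and not a size: the limit of >= 250000 nM in this assay, at which 1 of the 4 values shown sits.

Still open, on these data alone, is whether an amine or a carboxylic acid in place of trifluoromethyl on that aromatic carbon would move the number beyond the scatter of these values. The same question applies to a longer chain on the amide-type nitrogen.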